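A few compounds are considered here, and "the series" means these few. Any claim that something is new, unique, unknown or untested is made for them only; others in the source may bear on it.

Measured in an ADME assay on a cell-free system (plasma, Rattus norvegicus) for metabolic stability, read by LC-MS, with a stated time of 60 min, at 37 degrees C, tested at 50 uM; on this read-out higher numbers stand for a more stable compound and lower numbers for a less stable compound:

compound 1 `C[C@@H](O)[C@H]1C(=O)N2C3=C(S[C@@H]4CN[C@@H](C4)C(=O)Nc4cccc(c4)C(=O)OCCCCOC3=O)[C@H](C)[C@H]12`: 0%
compound 2 `CC(C)C(=O)OCOC(=O)C1=C(S[C@@H]2CN[C@H](C(=O)Nc3cccc(C(=O)O)c3)C2)[C@H](C)[C@@H]2[C@@H]([C@@H](C)O)C(=O)N12`: 0%
compound 3 `CC(C)C(=O)OCOC(=O)C1=C(S[C@@H]2CN[C@H](C(=O)Nc3cccc(C(=O)OCOC(=O)C(C)C)c3)C2)[C@H](C)[C@@H]2[C@@H]([C@@H](C)O)C(=O)N12`: 1%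

All three measured compounds are essentially gone after the stated time. Compound 2 sits level with compound 1 at the digits reported, and the two together give the two lowest numbers of the set; compound 3 stands only a number 1 percentage points higher from compound 2 to compound 3 (within the scatter) away, a difference within the scatter.

Compound 4 `C[C@@H](O)[C@H]1C(=O)N2C(C(=O)OCOC(=O)OC3CCCCC3)=C(S[C@@H]3CN[C@H](C(=O)Nc4cccc(C(=O)O)c4)C3)[C@H](C)[C@H]12` follows from compound 2 by one change: cyclohexyloxy in place of isopropyl on a carbonyl carbon. Among the compounds with values here, the only measured step that touches the same region is the one from compound 2 to compound 3, where an ((isopropylcarbonyl)oxy)methyl enters in place of hydrogen on an oxygen next to a carbonyl group, and that step was within the scatter. Within the data shown here, no measured pair compares isopropyl against cyclohexyloxy on a carbonyl carbon, so there is nothing that points to a shift away from the floor on which compounds 1, 2 and 3 all lie.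

In this assay compound 4 is therefore expected to show a number 2 percentage points higher from compound 2 to compound 4 (within the scatter), that is, no step beyond the scatter. The estimate for compound 4 is 2%, with a range from 0% to 12%.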

Compound 4, percent of the compound remaining: 0%
Compound 4: the middle estimate sits 2 percentage points above what was measured; the measured number falls inside the stated range.
By their numbers in this assay, from the lowest: compounds 1, 2, 4 and 3 (each within the scatter of the next).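

In this assay, within the data shown here, cyclohexyloxy in place of isopropyl on a carbonyl carbon gives no change at the digits printed from compound 2 to compound 4 (within the scatter), the first direct comparison of these two groups at this place. The change from ((isopropylcarbonyl)oxy)methyl to ((cyclohexyloxycarbonyl)oxy)methyl therefore brings no readable shift, but with compound 2 and compound 4 both at the bottom of the read-out, any real difference between the two groups could stay hidden. Nothing available offers an explanation for this result.

Still open, as far as these compounds go, is whether an amine or a longer alkyl chain on this carbonyl carbon would leave more compound remaining in this assay. It is also open whether any group at this place can lift the series clear of the scatter, since every compound shown lies at the same low end.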